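The compounds below may be only part of what the source reports. "The series", "measured", "known", "first", "only" and "open" are said of these compounds alone.

Measured so far in a functional assay on HUVEC cells (Homo sapiens) for inhibition, using NADPH, with a stated time of 2 h; on this read-out lower numbers stand for stronger inhibition and higher numbers for weaker inhibition:

compound 1, `Cc1c(COCCCCO)[nH]c2ccccc2c1=O`: 2600 nM
compound 2, `COC(C)(C)CCOc1cccc(OCc2[nH]c3ccccc3c(=O)c2C)c1`: 8.3 nM
compound 3, `Cc1c(COc2cccc(OCC3CCOCC3)n2)[nH]c2ccccc2c1=O`: 59 nM

Compound 2 stands lowest of the three numbers in this assay, and both gaps to the others are beyond the scatter: compound 3 sits nearest with its higher value, compound 1 furthest. Compound 2 is therefore the most potent of the measured set.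

The next compound, compound 4, `Cc1c(COc2cccc(OCC3CCOCC3)c2)[nH]c2ccccc2c1=O`, differs from compound 2 in one place: oxan-4-yl in place of 2-methoxy-2-methylpropyl on a saturated chain carbon bound to an oxygen on an aromatic ring. The group that leaves and the group that enters are of the same heavy-atom count and carry the same count of donors and acceptors; the entering group closes into a six-membered non-aromatic ring where the leaving one is open.

For the measured compounds named here, no measured step of exactly this kind exists in the set, so the expectation rests on the span of values seen. Compound 2 gives 8.3 nM and compound 3 gives 59 nM; a value for compound 4 between these seems most plausible. The step from compound 2 to compound 4 is expected to be a moderate loss, a 2.4-fold higher number from compound 2 to compound 4 (0.38 log units; beyond the scatter), possibly within the scatter. For compound 4 the estimate in this assay is 20 nM, with a range from 6 nM to 70 nM.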

Compound 4, half-maximal inhibitory concentration: 8.9 nM
The estimate for compound 4 lay 2.2-fold (0.35 log units) above the measured number; the measured number falls inside the stated range.
By their numbers in this assay, from the lowest: compounds 2 and 4 (each within the scatter of the next); then compound 3; then compound 1.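

In this assay, oxan-4-yl in place of 2-methoxy-2-methylpropyl on a saturated chain carbon bound to an oxygen on an aromatic ring gives a 1.1-fold higher number from compound 2 to compound 4 (0.03 log units; within the scatter), so the two compounds cannot be told apart on this read-out. For the compounds shown here, this is the first one-place comparison, and it shows that, for this pair, the open group and the six-membered non-aromatic ring are interchangeable at this place with no readable change in the number. Nothing at hand indicates why the two groups read alike.

Still open, going by these compounds, is whether the ring oxygen matters: cyclohexyl at this place would test that, and piperidin-4-yl would test a ring amine. A carboxylic acid on the same chain would show whether this place also accepts a group of a different kind.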